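The compounds below may be only part of what the source reports. "The series", "measured", "known", "first", "only" and "open" are said of these compounds alone.

Compound 1 `COc1cccc(-c2nc(SC)nc3sc(C(=O)NCC#N)c(N)c23)c1` gives the highest of the three numbers in a functional assay on HEK293 cells for agonist activity at Thyrotropin receptor (Homo sapiens), read by cAMP accumulation (on this read-out lower numbers stand for smaller maximal responses and higher numbers for larger maximal responses), at 3.6%, though every step to the others lies within the scatter. Compound 2 `CCNC(=O)c1sc2nc(SC)nc(-c3cccc(OC)c3)c2c1N` gives 2.3%, and compound 3 `COc1cccc(-c2nc(SC)nc3sc(C(=O)NNC(=O)OC(C)(C)C)c(N)c23)c1` gives 1.9%. The steps of a number 1.3 percentage points lower from compound 1 to compound 2 (within the scatter), a number 1.7 percentage points lower from compound 1 to compound 3 (within the scatter) and a number 0.4 percentage points lower from compound 2 to compound 3 (within the scatter) all concern the substituent on the amide-type nitrogen and all stay within the scatter. Within the data shown here, compound 4 `COc1cccc(-c2nc(SC)nc3sc(C(=O)N(C)C)c(N)c23)c1` differs from compound 1 by dimethylamino in place of (cyanomethyl)amino on a carbonyl carbon, a change that removes the amide hydrogen, which none of the measured steps did. Since all three measured steps at this position stayed within the scatter, no step beyond the scatter is expected in this assay, so for compound 4 a value of 2.5% is estimated, between 0% and 10%, a step of a number 1.1 percentage points lower from compound 1 to compound 4 (within the scatter).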

Compound 4, largest response reached (reported as efficacy), in percent of the reference or control that the assay uses: 4%
For compound 4 the middle estimate is 1.5 percentage points below the measured one; measured number inside the range.
By their numbers in this assay, from the lowest: compounds 3, 2, 1 and 4 (each within the scatter of the next).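

In this assay the dimethylamino group on the carbonyl carbon, with 0 hydrogen-bond donors, cannot be told apart from the three groups that keep the amide hydrogen, the steps being a number 0.4 percentage points higher from compound 1 to compound 4 (within the scatter) and a number 1.7 percentage points higher from compound 2 to compound 4 (within the scatter) and a number 2.1 percentage points higher from compound 3 to compound 4 (within the scatter) in this series. Losing the amide hydrogen therefore leaves the number within the scatter for these compounds. No evidence on the reason for this is available.

Open, as far as these compounds go, is whether a morpholine or a carboxylic acid in this place would give a step beyond the scatter. Also open, from the compounds shown here alone, is whether changes elsewhere on the shared core would do so.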